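The compounds below may be only part of what the source reports. "The series", "measured", "known", "first", "only" and "open" are said of these compounds alone.

Measured so far:
- compound 1, `CCCn1c(=O)n(C2CCC(COC(C)=O)O2)c2nc(NC(C)=O)nc(O)c21`, gives 100%
- compound 2, `Nc1nc(O)c2c(n1)n(C1OC(CO)[C@@H](O)[C@H]1O)c(=O)n2CC(O)CSc1ccccc1`, gives 12%
- compound 3, `C=CCn1c(=O)n(C2C=CC(CO)O2)c2nc(N)nc(O)c21`, gives 45%

All three were tested in a functional assay on the whole organism (B cells) with Mus musculus as the target; a lower number here means a smaller maximal response, a higher number a larger maximal response. Among the three numbers, compound 2 stands lowest; its nearest neighbour is compound 3, whose value is higher by a margin beyond the usual scatter, and compound 1 lies furthest away, higher still. No pair of these compounds differs in only one place, so none of the gaps can be pinned on a single change.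

Compound 4, `CCCCn1c(=O)n(C2OC(CO)[C@@H](O)[C@H]2O)c2nc(N)nc(O)c21`, has not yet been measured. It is related to compound 2 by one change: propyl in place of 1-hydroxy-2-(phenylsulfanyl)ethyl on a saturated chain carbon bound to an aromatic nitrogen. The group that leaves is large, carries a ring and one donor and two acceptors, while the group that enters is a short chain with none of these.

On the numbers shown, compounds with short, simple groups on that chain carbon, compound 1 and compound 3, reached higher maximal responses than compound 2. It is therefore expected that the step of a number 38 percentage points higher from compound 2 to compound 4 (beyond the scatter) will be upward and beyond the scatter. For compound 4 the estimated maximal response is 50%, within a range from 20% to 85%.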

Compound 4, largest response reached (reported as maximal response), in percent of the reference or control that the assay uses: 86%
Compound 4: the middle estimate sits 36 percentage points below what was measured, and the stated range ends below it.
By their numbers in this assay, from the lowest: compound 2; then compound 3; then compound 4; then compound 1.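

In this assay, for the compounds shown here, the swap of 1-hydroxy-2-(phenylsulfanyl)ethyl for propyl on a saturated chain carbon bound to an aromatic nitrogen gives a number 74 percentage points higher from compound 2 to compound 4 (beyond the scatter) and this is the first gap here that can be tied to a single change. It shows that this position is not silent: with the rest of the molecule held the same, the group in this place alone moves the maximal response by a large amount. Nothing measured here explains the step, and the two groups differ at once in size, ring, sulfur atom and hydroxyl, so the data cannot single out any one of these as the part that counts.

Which part of the larger group holds the response down therefore stays open, and a comparison of propyl with a benzyl group, which has a ring, or with a 2-hydroxyethyl group, which has a hydroxyl, would begin to separate the two. Whether a longer chain or an amine in this place would keep the response as high as propyl also remains an open question.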